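Adding a hydroxy group to the phenyl of compound 1

The source may report more compounds than this note shows. Statements on the series, on what has been measured and on what is new or still open speak of the compounds shown alone.

Of the compounds shown here, three sharing one core have been measured in a functional assay on A2780 cells (Homo sapiens) for antiproliferative activity, read by MTT assay, with a stated time of 48 h; a higher number here means a weaker inhibitor of growth, a lower number a stronger inhibitor of growth. Compound 1 `COC(=O)N1N=C(c2ccccc2)CC1c1cc(OC)c(OC)c(OC)c1` gives 2770 nM, the lowest number of the three and so the strongest inhibitor of growth among them. Compound 2 `CCCOC(=O)N1N=C(c2ccccc2)CC1c1cc(OC)c(OC)c(OC)c1` gives 10800 nM, and compound 3 `COC(=O)N1N=C(c2ccccc2)CC1c1ccc(OC)c(OC)c1` gives 29900 nM. Ethyl in place of hydrogen on the saturated chain carbon bound to the oxygen next to the carbonyl group gives a 3.9-fold higher number from compound 1 to compound 2 (0.59 log units; beyond the scatter). Hydrogen in place of methoxy on an aromatic carbon gives an 11-fold higher number from compound 1 to compound 3 (1.03 log units; beyond the scatter).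

Compound 4 `COC(=O)N1N=C(c2ccc(O)cc2)CC1c1cc(OC)c(OC)c(OC)c1` has not yet been measured. It carries hydroxy in place of hydrogen on an aromatic carbon, turning the phenyl of compound 1 into 4-hydroxyphenyl: hydroxy in place of hydrogen on an aromatic carbon.

Going by the values given here, no measured step touches this phenyl, so the two steps bear on the change only indirectly. They do show that both single changes made to compound 1 raised the number in this assay, one modestly and one by a large margin. A modest rise is therefore expected, near a 3.9-fold higher number from compound 1 to compound 2 (0.59 log units; beyond the scatter), though a change within the scatter would be no surprise. The expected step is a 2.2-fold higher number from compound 1 to compound 4 (0.34 log units; beyond the scatter). For compound 4 the estimated value is 6000 nM, within an expected range of 1500 nM to 25000 nM.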

Compound 4, concentration for 50% growth inhibition: 2520 nM
Estimate against measurement, compound 4: 2.4-fold (0.38 log units) above, and the stated range covers the measured number.
By their numbers in this assay, from the lowest: compounds 4 and 1 (each within the scatter of the next); then compound 2; then compound 3.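

In this assay, hydroxy in place of hydrogen on an aromatic carbon gives a 1.1-fold lower number from compound 1 to compound 4 (0.04 log units; within the scatter), so compound 1 and compound 4 cannot be told apart here. Going by these compounds alone, this is the first measured change on this phenyl, and it behaves differently from the two earlier single changes to compound 1, on the ester chain and on the methoxy-bearing ring, both of which raised the number beyond the scatter; the phenyl, at least for this one group in this one place, accepts an added hydroxy without a readable change in growth inhibition. Nothing measured here offers a reason for this result.

A single hydroxy says little about what else this place would accept, so an amine, a carboxylic acid or a longer chain such as propoxy on the phenyl could give quite different numbers. As far as these compounds go, it also remains open whether 4-hydroxyphenyl would behave the same way on the propyl ester of compound 2 or with the two methoxy groups of compound 3.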